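A hexyl-to-4-fluorophenyl swap with little expected change

The source may hold more compounds than are shown below. What is called first, only, known or untested is meant among the compounds shown, and "the series" means these compounds.

Of the compounds shown here, two of a shared core have been tested in an ADME assay on HeLa cells (Homo sapiens) for cytotoxicity, read by sulforhodamine B assay, with a stated time of 48 h, tested at 10 uM; on this read-out lower numbers stand for less inhibition and higher numbers for more inhibition at the one concentration tested (going by the name of the read-out). Compound 1 `COc1nc2ccc(Br)cc2cc1C(c1ccccc1)n1cc(C2CC2)nn1` gives -5.84% in this assay, and compound 2 `CCCCCCc1cn(C(c2ccccc2)c2cc3cc(Br)ccc3nc2OC)nn1` gives -0.97%. Compound 2 holds the higher of the two numbers, but the gap to compound 1 is within the scatter, so the two read-outs cannot be told apart. Among the measured compounds shown here, the only measured step is a number 4.9 percentage points higher from compound 1 to compound 2 (within the scatter). This step also changes the group on the same aromatic carbon of the five-membered aromatic ring with 3 nitrogen, so it bears directly on the question at hand.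

Compound 3 `COc1nc2ccc(Br)cc2cc1C(c1ccccc1)n1cc(-c2ccc(F)cc2)nn1` differs from compound 2 in one place: 4-fluorophenyl in place of hexyl on an aromatic carbon. The hexyl leaves and 4-fluorophenyl enters, a group of 7 heavy atoms with one six-membered aromatic ring of carbon only. For the measured compounds named here, since the one comparable step in this assay was within the scatter, and both measured numbers sit close to no inhibition, no step beyond the scatter is expected from compound 2 to compound 3, an expected change of a number 1 percentage points higher from compound 2 to compound 3 (within the scatter). The estimate for compound 3 in this assay is 0%, with a range from -12% to 14%.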

Compound 3, a percentage reported as inhibition, at one concentration (the size of the read-out at that concentration, not a potency): 4.27%
For compound 3 the middle estimate is 4.3 percentage points below the measured one; low and high end bracket the measured number.
By their numbers in this assay, from the lowest: compounds 1, 2 and 3 (each within the scatter of the next, the first and the last beyond it).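

In this assay, 4-fluorophenyl in place of hexyl on the aromatic carbon of the five-membered ring gives a number 5.2 percentage points higher from compound 2 to compound 3 (within the scatter), so this change, like the swap of cyclopropyl for hexyl before it, cannot be told apart from repeat scatter. Among the compounds shown here, what is new is the first step at this position that clears the scatter: 4-fluorophenyl in place of cyclopropyl gives a number 10.1 percentage points higher from compound 1 to compound 3 (beyond the scatter), a modest gap, while the hexyl of compound 2 stays within the scatter of both neighbours, so the three groups do not fall into clearly separate levels. No supporting measurement is available to account for this gap.

The compounds shown leave open how an amine or a carboxylic acid on this aromatic carbon would read in this assay, as hexyl and 4-fluorophenyl both carry no hydrogen-bond donors, no hydrogen-bond acceptors and no net charge. They also leave open whether plain phenyl would read like 4-fluorophenyl, which would show whether the fluorine matters to the modest gap or the aromatic ring alone is enough.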